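Inverting the Ring Stereocentre: Compound 3 to Compound 4

The source may report more compounds than this note shows. Statements on the series, on what has been measured and on what is new or still open speak of the compounds shown alone.

Compound 3 `C[C@@]1(c2ccc(Cl)cc2Cl)OC[C@@H](COc2ccc(N3CCN(c4ccc(NC(=O)NN)cc4)CC3)cc2)O1` gives 500 nM in a functional assay on cells (Medulloblastoma cell, Mus musculus) for antiproliferative activity, read by thymidine incorporation, with a stated time of 48 h (a higher number here means a weaker inhibitor of growth, a lower number a stronger inhibitor of growth), the lowest of the two numbers measured; compound 2 `C[C@]1(c2ccc(Cl)cc2Cl)OC[C@@H](COc2ccc(N3CCN(c4ccc(NC(=O)c5cccnc5)cc4)CC3)cc2)O1` gives 1100 nM. Compound 1 `C[C@@]1(c2ccc(Cl)cc2Cl)OC[C@@H](COc2ccc(N3CCN(c4ccc(NC(=O)c5cccnc5)cc4)CC3)cc2)O1` gives only a limit, > 10000 nM. Compound 4 `C[C@]1(c2ccc(Cl)cc2Cl)OC[C@@H](COc2ccc(N3CCN(c4ccc(NC(=O)NN)cc4)CC3)cc2)O1` differs from compound 3 in one way: the two compounds have the same atoms and bonds and differ only in configuration as drawn: 1 of 2 stereo elements differ; a stereocentre at a saturated ring carbon is drawn R in compound 3 and S in compound 4. Within the data shown here, two measured steps bear on this. The same inversion is seen in an at least 9.0-fold lower number from compound 1 to compound 2 (0.95 log units; beyond the scatter), because of the fact that compounds 1 and 2 differ only in the configuration as drawn; that step is known only as a lower bound due to the limit of > 10000 nM in this assay, at which 1 of the 3 values shown sits. The other step, an at least 20-fold lower number from compound 1 to compound 3 (1.30 log units; beyond the scatter), changes the group on the carbonyl carbon rather than the configuration. The step to compound 4 is therefore expected to lower the number in this assay by a comparable margin, a 6.3-fold lower number from compound 3 to compound 4 (0.80 log units; beyond the scatter). Compound 4 is estimated at 80 nM, within 25 nM to 250 nM.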

Compound 4, concentration for 50% growth inhibition: 2800 nM
Estimate against measurement, compound 4: 35-fold (1.54 log units) below; measured number above the stated range.
By their numbers in this assay, from the lowest: compound 3; then compound 2; then compound 4. At a limit, above all of these: compound 1.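

In this assay the inversion now raises the number, a 5.6-fold higher number from compound 3 to compound 4 (0.75 log units; beyond the scatter), whereas with pyridin-3-yl on the carbonyl carbon it lowered it, an at least 9.0-fold lower number from compound 1 to compound 2 (0.95 log units; beyond the scatter): the configuration giving the lower number differs with the group on the carbonyl carbon. Compound 1 stands at a limit, > 10000 nM. The exchange of pyridin-3-yl for aminoamino also reverses direction with configuration, a 2.5-fold higher number from compound 2 to compound 4 (0.41 log units; beyond the scatter), and the two steps do not agree: the same change on two cores in this assay, an at least 20-fold lower number (1.30 log units; beyond the scatter) from compound 1 to compound 3 and a 2.5-fold higher number (0.41 log units; beyond the scatter) from compound 2 to compound 4, at least 50-fold (1.70 log units) apart, beyond the scatter of two such steps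

Going by these compounds, whether the reversal holds for other groups on the carbonyl carbon, such as methyl or a simple amine, stays open.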